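The compounds below may be only part of what the source reports. "The series", "measured", "known", "first", "only" and "open" are said of these compounds alone.

Measured compounds in an assay on CHO cells for displacement of a labelled ligand from 5-hydroxytryptamine receptor 1B (Homo sapiens); a lower number here means a stronger inhibitor, a higher number a weaker inhibitor:
compound 1, `c1ccc2c(c1)CCC2NC1CCN(CCCc2c[nH]c3ccc(-n4cnnc4)cc23)CC1`, gives 280 nM
compound 2, `CN(C1CCN(CCCc2c[nH]c3ccc(-n4cnnc4)cc23)CC1)S(=O)(=O)c1ccccc1`, gives 10 nM
compound 3, `C[C@H](NCC1CCN(CCCc2c[nH]c3ccc(-n4cnnc4)cc23)CC1)c1ccccc1`, gives 58 nM

Compound 3 stands second highest of the three numbers, beyond the scatter from both neighbours, with a 4.8-fold lower number from compound 1 to compound 3 (0.68 log units; beyond the scatter) below it and a 5.8-fold higher number from compound 2 to compound 3 (0.76 log units; beyond the scatter) above it. Compound 4, `CN(Cc1cccs1)C1CCN(CCCc2c[nH]c3ccc(-n4cnnc4)cc23)CC1`, is the untested member; it differs from compound 3 in one place: methyl((thiophen-2-yl)methyl)amino in place of ((1-phenylethyl)amino)methyl on a saturated ring carbon. The step that bears most on it is a 5.8-fold higher number from compound 2 to compound 3 (0.76 log units; beyond the scatter), since compound 2 also carries a methyl-bearing amino group attached directly to the saturated ring carbon; the entering group of compound 4 resembles that arrangement more than the arrangement in compound 3. A modest step toward a lower number is therefore expected, a 2.9-fold lower number from compound 3 to compound 4 (0.46 log units; beyond the scatter), without reaching the value of compound 2. Compound 4 is estimated at 20 nM, within 6 nM to 65 nM.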

Compound 4, half-maximal inhibitory concentration: 140 nM
Beside the measured number, compound 4's estimate is 7.0-fold (0.85 log units) below it; measured number outside the range, above it.
By their numbers in this assay, from the lowest: compound 2; then compound 3; then compounds 4 and 1 (each within the scatter of the next).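

In this assay the methyl-bearing amine on the saturated ring carbon does not carry the low number by itself: (thiophen-2-yl)methyl in place of phenylsulfonyl on that nitrogen gives a 14-fold higher number from compound 2 to compound 4 (1.15 log units; beyond the scatter) and is the largest new step. Against the ((1-phenylethyl)amino)methyl group, the entering methyl((thiophen-2-yl)methyl)amino group gives a 2.4-fold higher number from compound 3 to compound 4 (0.38 log units; beyond the scatter), while a 2.0-fold lower number from compound 1 to compound 4 (0.30 log units; within the scatter) leaves compound 4 unseparated from compound 1. No measured evidence accounts for these steps.

Open, on these data alone, is whether a methanesulfonyl or benzoyl group on that amine nitrogen would fall nearer compound 2 or compound 4.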